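The source may hold more compounds than are shown below. What is called first, only, known or untested is meant among the compounds shown, and "the series" means these compounds.

Compound 2 `CC1CN(c2cnc3c(C(N)=O)nn(C(C)c4ccc(Cl)cc4Cl)c3n2)CCC1N1CCCCC1`, measured in a functional assay on cells for antagonist activity at C-C chemokine receptor type 4 (Homo sapiens), read by fluorescence and calcium flux, with stated times of 2.5 s and 45 s (a lower number here means a stronger inhibitor, a higher number a weaker inhibitor), gives 228 nM. Among the three compounds measured, this is the second highest number. Compound 1 `Cc1nn([C@H](C)c2ccc(Cl)cc2Cl)c2nc(N3CC[C@H](N4CCCC4)[C@H](C)C3)cnc12` gives 69 nM in this assay, a lower number that lies beyond the scatter. Compound 3 `CC(c1ccc(Cl)cc1Cl)n1ncc2ncc(N3CCC(N4CCCCC4)CC3)nc21` gives 2580 nM in this assay, a higher number that also lies beyond the scatter. Compound 4 `CC1CN(c2cnc3c(C#N)nn(C(C)c4ccc(Cl)cc4Cl)c3n2)CCC1N1CCCCC1` has not yet been measured. It differs from compound 2 in a single place: cyano in place of carbamoyl on an aromatic carbon. Within the data shown here, no measured pair shows this exact change, so its effect is uncertain; the expected step is small, toward a lower number, or none beyond the scatter. For compound 4 the estimated value in this assay is 150 nM, with a range from 50 nM to 450 nM. This corresponds to an expected step of a 1.5-fold lower number from compound 2 to compound 4 (0.18 log units; within the scatter).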

Compound 4, half-maximal inhibitory concentration: 251 nM
Beside the measured number, compound 4's estimate is 1.7-fold (0.22 log units) below it, within the range that was stated.
By their numbers in this assay, from the lowest: compound 1; then compounds 2 and 4 (each within the scatter of the next); then compound 3.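

In this assay, cyano in place of carbamoyl on this aromatic carbon gives a 1.1-fold higher number from compound 2 to compound 4 (0.04 log units; within the scatter). Among these compounds, this is the first single-place comparison at this position, and it shows that losing the hydrogen-bond donor of carbamoyl, along with one heavy atom, leaves compounds 2 and 4 indistinguishable in this assay. No measurement at hand explains why the two groups read alike. From the compounds shown here alone, whether a carboxylic acid or an aminomethyl group on this carbon would also read alike remains open. Compounds 1 and 3 differ from compound 2 in more than one place, so they cannot settle this.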